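Replacing a Cyano Group Where Only Limits Are Known

This account rests on a few compounds, and the source may have more. Where it says the series, first, only, none or still open, it means among the compounds named here.

Compound 1 `CCC1(Cc2ccccc2)OS(=O)(=O)C=C1OCC#N` was tested in an ADME assay on HEL cells (Homo sapiens) for cytotoxicity, with a stated time of 3 days; a higher number here means that more compound is tolerated, a lower number that less compound is tolerated. In this assay compound 1 gives > 400000 nM, and that figure is a limit of the assay rather than a measured number (the limit of > 400000 nM in this assay, at which 1 of the 3 values shown sits). Two further compounds show the same kind of result. Compound 2 `CCC1(Cc2ccccc2)OS(=O)(=O)CC1=O` gives > 100000 nM, which is also only a limit (the limit of > 100000 nM in this assay, at which 1 of the 3 values shown sits). Compound 3 `CC1(C(c2ccccc2)c2ccccc2)OS(=O)(=O)C=C1OCc1ccccc1` gives >= 400000 nM, once more a limit (the limit of >= 400000 nM in this assay, at which 1 of the 3 values shown sits). Among the measured compounds shown here, none of these three differs from another in a single place, so no step between measured compounds can be stated; all that the numbers show is that each compound was tolerated up to the highest concentration tried.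

Compound 4 `CCC1(Cc2ccccc2)OS(=O)(=O)C=C1OCc1ccc(OC)cc1` has not yet been measured. It differs from compound 1 in one spot: 4-methoxyphenyl in place of cyano on a saturated chain carbon bound to an oxygen on an unsaturated carbon. With only limits available, no direction of change can be read from the data, and the step is expected to stay within the usual scatter. Compound 4 is therefore expected to give about 400000 nM, within a range from 150000 nM to 800000 nM. The expected step of a number no higher from compound 1 to compound 4 (the limit leaves the size open) is thus essentially none.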

Compound 4, minimum cytotoxic concentration: >= 200000 nM
Compound 4: a limit, no number (the forecaster's own chance of this, stated with the estimate: 70%); the middle value does not contradict the limit.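

Among the compounds shown here, compound 1 and compound 4 both give only limits in this assay, and no step between them can be read. The compounds shown leave open at what concentration any of them would harm the cells, and whether 4-methoxyphenyl in place of cyano shifts that concentration at all.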